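Aryl versus cyclohexyl on the amine nitrogen

A few compounds are considered here, and "the series" means these few. Any claim that something is new, unique, unknown or untested is made for them only; others in the source may bear on it.

In a functional assay on MGC-803 cells (Homo sapiens) for inhibition, read by sulforhodamine B assay (on this read-out higher numbers stand for weaker inhibition and lower numbers for stronger inhibition), compound 1 `Cc1ccc(NC2=CC(=O)c3c(nc4n3[C@H]3OC[C@@H](O)[C@H]3OC4)C2=O)cc1C` gives 1050 nM. Compound 2 `O=C1C(NC2CCCCC2)=CC(=O)c2c1nc1n2[C@H]2OC[C@@H](O)[C@H]2OC1` gives > 8000 nM, which is a limit of the assay and not a number. Compound 2 therefore stands at the limit of > 8000 nM in this assay, at which 1 of the 2 values shown sits.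

The next change leads to compound 3 `CCOc1ccccc1NC1=CC(=O)c2c(nc3n2[C@H]2OC[C@@H](O)[C@H]2OC3)C1=O`: 2-ethoxyphenyl in place of cyclohexyl on an amine nitrogen. Among the measured compounds shown here, the only measured step bearing on it is an at least 7.6-fold higher number from compound 1 to compound 2 (0.88 log units; beyond the scatter), which lies beyond the scatter and came with cyclohexyl in place of 3,4-dimethylphenyl. The new change runs the opposite way, from cyclohexyl to a six-membered aromatic ring, so a lower number is expected in this assay. Its size stays loose, since one end is only a limit and 2-ethoxyphenyl is unmeasured. The expected step is an at least 4.4-fold lower number from compound 2 to compound 3 (0.64 log units; beyond the scatter). For compound 3 the estimate is 1800 nM, with an expected range of 600 nM to 6000 nM.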

Compound 3, half-maximal inhibitory concentration: 2830 nM
Compound 3: the middle estimate sits 1.6-fold (0.20 log units) below what was measured; measured number inside the range.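

Compound 2 gives > 8000 nM, a limit of the assay and not a number: the limit of > 8000 nM in this assay, at which 1 of the 3 values shown sits.

In this assay, replacing cyclohexyl on the amine nitrogen with 2-ethoxyphenyl gives an at least 2.8-fold lower number from compound 2 to compound 3 (0.45 log units; beyond the scatter), so a second aryl group, this one with an ether oxygen, also reads stronger than cyclohexyl. The two aryl groups are not interchangeable, however: there is a 2.7-fold higher number from compound 1 to compound 3 (0.43 log units; beyond the scatter), which leaves 3,4-dimethylphenyl the stronger of the pair and shows that the read-out depends on what the six-membered aromatic ring carries.

Going by these compounds, it remains open whether the gap between compound 1 and compound 3 follows the ethoxy group itself or the positions of the ring substituents, and an unsubstituted phenyl would give the reference point. On these data alone, how an amine or a carboxylic acid on the aromatic ring would read is also open.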